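Piperidinylmethyl analogue of compound 3: cytotoxicity outlook

The source may report more compounds than this note shows. Statements on the series, on what has been measured and on what is new or still open speak of the compounds shown alone.

Working notes on cytotoxicity in the series. In an ADME assay on Vero cells (Chlorocebus sabaeus) for cytotoxicity, with a stated time of 7 days (on this read-out lower numbers stand for higher toxicity in this test and higher numbers for lower toxicity in this test), compound 1 `COc1cccc(CN2C(=O)CN(C(=O)c3cc4cc(OC)ccc4o3)C[C@@H]2CCc2ccccc2)c1` gives 4500 nM. Compound 2 `COc1ccc2[nH]c(C(=O)N3CC(=O)N(Cc4ccccc4)[C@@H](CCc4ccccc4)C3)cc2c1` reaches only a limit of this assay, > 30000 nM. Compound 3 `COc1ccc2[nH]c(C(=O)N3CC(=O)N(Cc4ccccc4)[C@@H](COc4ccccc4)C3)cc2c1` likewise reaches only a limit, > 10000 nM. For the measured compounds named here, the single one-place step in the set, a step that the two limits leave unreadable from compound 2 to compound 3, is accordingly not readable in size. Compound 3 thus stands on a limit rather than a number in this assay, and of the three values shown one further value is also a limit; only compound 1 carries a number.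

Compound 4 `COc1ccc2[nH]c(C(=O)N3CC(=O)N(Cc4ccccc4)[C@@H](CN4CCCCC4)C3)cc2c1` differs from compound 3 by piperidin-1-yl in place of phenoxy on a saturated chain carbon bound to a saturated ring carbon. Going by the values given here, no measured step bears directly on this exchange, and the one step that sits at the same chain position, benzyl to phenoxy, is hidden by the two limits the limit of > 10000 nM in this assay, at which 1 of the 3 values shown sits, and (the limit of > 30000 nM in this assay, at which 1 of the 3 values shown sits). Two of the three values shown are limits, the limit of > 10000 nM in this assay, at which 1 of the 3 values shown sits, and (the limit of > 30000 nM in this assay, at which 1 of the 3 values shown sits), and compound 1 is the only numbered point. On that basis the expectation for compound 4 in this assay is a value at or near a limit, with no direction beyond the scatter claimed. The step expected from this exchange is a step that the limit leaves unreadable from compound 3 to compound 4. Compound 4 is estimated at 15000 nM, with a range from 4000 nM to 60000 nM.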

Compound 4, half-maximal cytotoxic concentration: 76900 nM
Estimate against measurement, compound 4: 5.1-fold (0.71 log units) below; measured number above the stated range.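

For the compounds shown here, no step from compound 3 or from compound 2 to compound 4 can be read in this assay: compound 3 and compound 2 each stand on a limit, not a number. The compounds shown leave open the size of any difference among benzyl, phenoxy and piperidin-1-yl on a saturated chain carbon bound to a saturated ring carbon.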